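Replacing the 2-Bromophenyl Arm: Three Measured, One Expected

The compounds below may be only part of what the source reports. "The series", "measured", "known", "first", "only" and "open" are said of these compounds alone.

Three compounds have been tested in a toxicity assay on GES1 cells (Homo sapiens) for inhibition, read by MTT assay, with a stated time of 72 h; a lower number here means a stronger inhibitor, a higher number a weaker inhibitor:
- compound 1 `Cc1cc(N2CC[C@@H](C)[C@@H](N(C)c3ncnc4[nH]ccc34)C2)n2nc(SCc3ccccc3Br)nc2n1` gives > 100000 nM, which is a limit of the assay and not a number.
- compound 2 `Cc1cc(N2CC[C@@H](C)[C@@H](N(C)c3ncnc4[nH]ccc34)C2)n2nc(SCCc3ccccc3)nc2n1` gives 66200 nM.
- compound 3 `Cc1ccc(CSc2nc3nc(C)cc(N4CC[C@@H](C)[C@@H](N(C)c5ncnc6[nH]ccc56)C4)n3n2)cc1` gives 82500 nM.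

Compound 1 therefore stands only at a limit, not at a measured number (the limit of > 100000 nM in this assay, at which 1 of the 3 values shown sits). Compound 4 `Cc1cc(N2CC[C@@H](C)[C@@H](N(C)c3ncnc4[nH]ccc34)C2)n2nc(SCc3ccc([N+](=O)[O-])cc3)nc2n1` has not yet been measured. It differs from compound 1 in one place: 4-nitrophenyl in place of 2-bromophenyl on a saturated chain carbon bound to a sulfur. Going by the values given here, two measured steps bear on this change. Each swaps the same 2-bromophenyl for another group on the same carbon: an at least 1.5-fold lower number from compound 1 to compound 2 (0.17 log units; that floor lies within the scatter) and an at least 1.2-fold lower number from compound 1 to compound 3 (0.08 log units; that floor lies within the scatter). Both are small, and their floors lie within the usual scatter. The 4-nitrophenyl replacement is therefore expected to behave like the benzyl and 4-methylphenyl replacements, so a step of an at least 1.1-fold lower number from compound 1 to compound 4 (0.07 log units; that floor lies within the scatter) in this assay is expected, meaning none beyond the scatter. Compound 4 is estimated at 85000 nM, between 45000 nM and 160000 nM, with a real chance that only a limit is again reported.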

Compound 4, half-maximal inhibitory concentration: 36600 nM
Compound 4: middle estimate off by 2.3-fold (0.37 log units), on the high side, and the stated range ends above it.
By their numbers in this assay, from the lowest: compounds 4, 2 and 3 (each within the scatter of the next, the first and the last beyond it). At a limit, above all of these: compound 1.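

In this assay, the 4-nitrophenyl arm gives the first replacement on this saturated chain carbon whose step clears the scatter: an at least 2.7-fold lower number from compound 1 to compound 4 (0.43 log units; beyond the scatter). That step is only a floor, because compound 1 stands at a limit and not at a number: the limit of > 100000 nM in this assay, at which 1 of the 4 values shown sits. Nitro in place of methyl on an aromatic carbon is also a readable step, a 2.3-fold lower number from compound 3 to compound 4 (0.35 log units; beyond the scatter), so the group carried on the ring changes the number here, whereas 4-nitrophenyl in place of benzyl gives a 1.8-fold lower number from compound 2 to compound 4 (0.26 log units; within the scatter).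

The compounds shown leave open whether this shift belongs to nitro itself or would also appear with an amine, a nitrile or a carboxylic acid on that ring carbon. They also leave open whether 4-nitrophenyl on a longer chain would move the number further.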